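The source may hold more compounds than are shown below. What is called first, only, known or untested is meant among the compounds shown, and "the series" means these compounds.

Of the compounds shown here, two have been measured so far in a functional assay on PC-3 cells (Homo sapiens) for cytotoxicity, read by sulforhodamine B assay, with a stated time of 48 h; a lower number here means a stronger inhibitor, a higher number a weaker inhibitor. Compound 1 `O=C(c1cccnc1)c1ccccc1O` gives 33400 nM there, and compound 2 `O=C(c1cccnc1)c1cc(Cl)cc(Cl)c1O` gives 28700 nM in this assay; these two numbers lie within the usual scatter of each other, so compound 2 stands alongside compound 1 rather than apart from it. Compound 3 `O=C(c1cccnc1)c1cc(Cl)ccc1O` differs from compound 2 in one place: hydrogen in place of chloro on an aromatic carbon. Compound 1 carries no chloro and gives 33400 nM in this assay, so for compound 3 the expected step is a 1.1-fold higher number from compound 2 to compound 3 (0.03 log units; within the scatter), none beyond the scatter. Compound 3 is expected to give 31000 nM in this assay, within 15000 nM to 65000 nM.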

Compound 3, half-maximal inhibitory concentration: 24800 nM
Estimate against measurement, compound 3: 1.3-fold (0.10 log units) above, within the range that was stated.
By their numbers in this assay, from the lowest: compounds 3, 2 and 1 (each within the scatter of the next).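

In this assay, hydrogen in place of the chloro ortho to the hydroxy group brings a 1.2-fold lower number from compound 2 to compound 3 (0.06 log units; within the scatter) and so leaves the number inside the scatter. A single chloro on the core of compound 1 does no more, with a 1.3-fold lower number from compound 1 to compound 3 (0.13 log units; within the scatter), so neither one chloro nor a second separates these compounds here. No measurement available bears on why these values lie so close. From the compounds shown here alone, whether an amine or a methoxy group at the position ortho to the hydroxy group would move the number beyond the scatter stays open.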